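This account rests on a few compounds, and the source may have more. Where it says the series, first, only, none or still open, it means among the compounds named here.

Three compounds with a shared core have been examined in an assay on isolated protein for inhibition of leukotriene B4 receptor 1 (Homo sapiens), tested at 10 uM; a lower number here means less inhibition, a higher number more inhibition at the concentration tested (going by the name of the read-out). Compound 1 `COCc1cc(C(C)=O)c(O)cc1OCCCCCCC#N` gives 47%. Compound 2 `CCc1cc(C(C)=O)c(O)cc1OCCCCC(C)(C)C#N` gives 79%, the highest of the three numbers. Compound 3 `C#CCCCCOc1cc(O)c(C(C)=O)cc1CC=C` gives 74%, a number that lies within the scatter of compound 2, so no order between these two can be drawn; compound 1, by contrast, falls beyond the scatter below compound 2.

Compound 4 `CCc1cc(C(C)=O)c(O)cc1OCCCCc1nnn[nH]1` is still to be measured in this assay. It differs from compound 2 in a single place: 1H-tetrazol-5-yl in place of 1-cyano-1-methylethyl on a saturated chain carbon, four bonds along the chain from an oxygen on an aromatic ring. For the measured compounds named here, no pair of measured compounds shows a change of this kind, so neither size nor direction of the step can be read from a precedent. Given the value of compound 2 at 79%, the step from compound 2 to compound 4 is expected to be small, a number 4 percentage points lower from compound 2 to compound 4 (within the scatter), and not to reach beyond the scatter. Compound 4 is therefore estimated to give 75% in this assay, with a range from 45% to 95%.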

Compound 4, a percentage reported as inhibition, at one concentration (the size of the read-out at that concentration, not a potency): 49%
The estimate for compound 4 lay 26 percentage points above the measured number; measured number inside the range.
By their numbers in this assay, from the lowest: compounds 1 and 4 (each within the scatter of the next); then compounds 3 and 2 (each within the scatter of the next).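

In this assay, for the compounds shown here, the exchange of 1-cyano-1-methylethyl for 1H-tetrazol-5-yl on a saturated chain carbon, four bonds along the chain from an oxygen on an aromatic ring, gives a number 30 percentage points lower from compound 2 to compound 4 (beyond the scatter) and is the only readable step at this position. The group at this place therefore matters to the read-out, and since the two groups match in heavy atoms, that count alone does not set the number. Nothing measured here says what lies behind this lower number.

From the compounds shown here alone, whether a carboxylic acid at the same place would give a number nearer that of compound 2 or that of compound 4 remains open. So does whether a longer chain carrying the 1H-tetrazol-5-yl would change the result.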